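Trifluoromethyl on the anilino ring of an amidine series

A few compounds are considered here, and "the series" means these few. Any claim that something is new, unique, unknown or untested is made for them only; others in the source may bear on it.

Measured so far in a functional assay on MDA-MB-231 cells (Homo sapiens) for cytotoxicity, read by MTT assay, with a stated time of 72 h; on this read-out lower numbers stand for stronger inhibition and higher numbers for weaker inhibition:
compound 1 `COc1ccc(Cn2nc(-c3ccccc3)c3cc(C(=N)Nc4ccccc4)nc(NC4CCCCC4)c32)cc1` 3400 nM
compound 2 `N=C(Nc1ccccc1)c1cc2c(-c3ccccc3)n[nH]c2c(NC2CCCCC2)n1` 1710 nM
compound 3 `COc1ccc(Cn2cc3cc(C(=N)Nc4ccccc4)ncc3n2)cc1` 1520 nM

Compound 3 carries the lowest of the three numbers in this assay, but the gap to compound 2 lies within the scatter, so the two cannot be told apart; only compound 1 stands beyond the scatter, with a higher number. Among the measured compounds shown here, the one step between compounds differing in a single place is a 2.0-fold lower number from compound 1 to compound 2 (0.30 log units; within the scatter), which concerns a group on an aromatic nitrogen and not the anilino ring.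

Compound 4 `COc1ccc(Cn2cc3cc(C(=N)Nc4cccc(C(F)(F)F)c4)ncc3n2)cc1` differs from compound 3 by trifluoromethyl in place of hydrogen on an aromatic carbon. For the measured compounds named here, no measured pair changes the anilino ring, so there is nothing in these three numbers that bears on a trifluoromethyl entering there; the only step known is on the other side of the core and is itself within the scatter.

The expectation for the step to compound 4 is therefore none beyond the scatter, a 1.0-fold lower number from compound 3 to compound 4 (0.01 log units; within the scatter). Compound 4 is estimated at 1500 nM in this assay, with a range from 600 nM to 3800 nM.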

Compound 4, half-maximal inhibitory concentration: 15500 nM
The estimate for compound 4 lay 10-fold (1.01 log units) below the measured number; the measured number lies above the stated range.
By their numbers in this assay, from the lowest: compounds 3, 2 and 1 (each within the scatter of the next, the first and the last beyond it); then compound 4.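

In this assay, among the compounds shown here, the anilino ring is the first place where a single change gives a step beyond the scatter: a 10-fold higher number from compound 3 to compound 4 (1.01 log units; beyond the scatter), with trifluoromethyl in place of hydrogen on an aromatic carbon, meta to a large group. The only earlier step, a 2.0-fold lower number from compound 1 to compound 2 (0.30 log units; within the scatter), concerned a group on an aromatic nitrogen in a different parent and stayed within the scatter, so the anilino ring is the one place shown so far where inhibition in this cell assay clearly weakens with a substituent. Nothing available bears on the reason for the size of this step.

The compounds shown leave open whether the weakening belongs to trifluoromethyl itself or to any group at this place, which a single fluorine, a methyl or a methoxy on the same carbon would help to separate, and whether trifluoromethyl on another carbon of the ring would give a step of like size. Also open, from the compounds shown here alone, is whether phenyl to 3-(trifluoromethyl)phenyl carries the same step on the core of compound 2, which has a hydrogen on the aromatic nitrogen and further groups on the core.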